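A few compounds are considered here, and "the series" means these few. Any claim that something is new, unique, unknown or untested is made for them only; others in the source may bear on it.

Measured so far:
compound 1 `O=C(Nc1ccc2nc(NC(=O)C3CCCCC3)sc2c1)c1ccccc1Oc1ccccc1` — 0.1 ug/mL
compound 2 `COc1ccc(C(=O)Nc2ccc3nc(NC(=O)C4CCCCC4)sc3c2)cc1` — 4.9 ug/mL
compound 3 `O=C(Nc1ccc2nc(NC(=O)C3CCCCC3)sc2c1)c1ccc(Cl)cc1Cl` — > 4 ug/mL

In a functional assay on WI-38 VA13 cells (Homo sapiens) for cytotoxicity (a higher number here means that more compound is needed for the effect, a lower number that less compound is needed), compound 1 gives 0.1 ug/mL. Compound 2 gives 4.9 ug/mL in this assay. For compound 3 this assay reports only a limit, > 4 ug/mL, so its true value is not known as a number. Compound 3 therefore stands at the limit of > 4 ug/mL in this assay, at which 1 of the 3 values shown sits, and the step between compound 2 and compound 3, a step that the limit leaves unreadable from compound 2 to compound 3, cannot be read as a size.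

Compound 4 `Cc1nc(C)c(C(=O)Nc2ccc3nc(NC(=O)C4CCCCC4)sc3c2)s1` differs from compound 3 in one place: 2,4-dimethyl-1,3-thiazol-5-yl in place of 2,4-dichlorophenyl on a carbonyl carbon. Within the data shown here, no measured step covers this kind of exchange, and the only step recorded that involves compound 3 is the unreadable one from compound 2. What can be said is that compound 2 and compound 3 both sit in the weak region of this assay, while compound 1 stands well apart from them.

With nothing to read from, compound 4 is expected to remain near that weak region, and the step that the limit leaves unreadable from compound 3 to compound 4 is estimated to be small or itself unreadable. Compound 4 is estimated at 5 ug/mL in this assay, with a range from 1.5 ug/mL to 20 ug/mL.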

Compound 4, half-maximal effective concentration: 0.39 ug/mL
For compound 4 the middle estimate is 13-fold (1.11 log units) above the measured one; the measured number lies below the stated range.
By their numbers in this assay, from the lowest: compound 1; then compound 4; then compound 2.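

In this assay, placing 2,4-dimethyl-1,3-thiazol-5-yl on the carbonyl carbon whose other neighbour is the amide-type nitrogen gives an at least 10-fold lower number from compound 3 to compound 4 (1.01 log units; beyond the scatter), and it also gives a 13-fold lower number from compound 2 to compound 4 (1.10 log units; beyond the scatter). This shows that a large drop in the number can be reached at this position with a five-membered aromatic ring with 2 hetero atoms, and not only with the group carried by compound 1, which gives 0.1 ug/mL against 0.39 ug/mL for compound 4, so compound 1 still has the lower printed number. The step from compound 3 gives only a lower bound on its size, not an exact size, because compound 3 is recorded only as a limit: the limit of > 4 ug/mL in this assay, at which 1 of the 4 values shown sits.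

The compounds shown leave open whether the lower number goes with the ring and its hetero atoms or with its two methyl groups, and a plain 1,3-thiazol-5-yl group would separate the two. They also leave open how a group carrying an amine or a carboxylic acid would stand at this position, and whether the change would hold with a different group on the other amide of the shared core.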